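Swapping the 4-methoxyphenyl group of compound 2

The compounds below may be only part of what the source reports. "The series", "measured", "known", "first", "only" and "open" are said of these compounds alone.

Measured so far in an ADME assay (liver) for metabolic stability, with Liver microsome (Rattus norvegicus) as the target, using microsomes; on this read-out lower numbers stand for slow clearance and higher numbers for fast clearance:
Compound 1 `O=C(O)c1csc(-n2nc(-c3ccc(F)cc3)c3ccccc32)n1`: 278 mL/min/kg
Compound 2 `COc1ccc(-c2nn(-c3nc(C(=O)O)cs3)c3ccccc23)cc1`: 618 mL/min/kg

Compound 2 has the higher of the two numbers, at 618 mL/min/kg, so it sits at the fast-clearing end of this small set. Compound 3 `O=C(O)c1csc(-n2nc(C3=CCCCC3)c3ccccc32)n1` is not yet measured and differs from it as follows: cyclohex-1-en-1-yl in place of 4-methoxyphenyl on an aromatic carbon. Among the measured compounds shown here, only one measured step bears on this change. It is a 2.2-fold higher number from compound 1 to compound 2 (0.35 log units; beyond the scatter), a modest step made within the aromatic group that compound 3 gives up. For the measured compounds named here, no measured compound shows a non-aromatic ring at this place, so the evidence is indirect. Compound 3 no longer carries the methoxy group, and so a modest move back down seems more likely than a further rise. The expected change is a 1.5-fold lower number from compound 2 to compound 3 (0.19 log units; within the scatter), an estimate that stays small. For compound 3 the expected number is 400 mL/min/kg, with an estimated range from 180 mL/min/kg to 900 mL/min/kg.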

Compound 3, clearance: 490 mL/min/kg
For compound 3 the middle estimate is 1.2-fold (0.09 log units) below the measured one, and the stated range covers the measured number.
By their numbers in this assay, from the lowest: compounds 1, 3 and 2 (each within the scatter of the next, the first and the last beyond it).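

Replacing the aromatic ring at this place with a non-aromatic one makes no clear difference: in this assay, cyclohex-1-en-1-yl in place of 4-methoxyphenyl gives a 1.3-fold lower number from compound 2 to compound 3 (0.10 log units; within the scatter) and stays within the usual scatter. Set against the 4-fluorophenyl group, the same ring gives a 1.8-fold higher number from compound 1 to compound 3 (0.25 log units; within the scatter) and is again not separated from it, even though the two aromatic compounds are separated from each other. An aromatic ring at this place is therefore not needed for clearance to stay in the range these compounds span, and no measurement here explains these numbers.

Still open, as far as these compounds go, is how a fully saturated cyclohexyl ring, without the double bond, would compare at this place. Also open, from the compounds shown here alone, is what an open-chain group, such as a butyl chain, or a ring carrying an amine would do there.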